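A Dimethylamino Analogue of a Carboxy Compound at the Limit

The source may report more compounds than this note shows. Statements on the series, on what has been measured and on what is new or still open speak of the compounds shown alone.

Compound 1 `CSc1ccc(/C=C(/SCc2ccc(Cl)cc2)C(=O)c2ccc(Cl)cc2)cc1` gives 25000 nM in a functional assay on DU-145 cells (Homo sapiens) for inhibition, read by trypan blue exclusion, with a stated time of 96 h; on this read-out lower numbers stand for stronger inhibition of growth and higher numbers for weaker inhibition of growth. Compound 2 `CSc1ccc(/C=C(/SCc2ccc(Cl)cc2)C(=O)c2ccc(C(=O)O)cc2)cc1` carries carboxy in place of chloro on an aromatic carbon, and in this assay compound 2 reaches only the limit of the assay, > 100000 nM. The step of an at least 4.0-fold higher number from compound 1 to compound 2 (0.60 log units; beyond the scatter) is therefore set by the limit of > 100000 nM in this assay, at which 1 of the 2 values shown sits, so compound 2 stands at the weaker end of the two values shown, with no number of its own. Compound 3 `CN(C)c1ccc(/C=C(/SCc2ccc(Cl)cc2)C(=O)c2ccc(C(=O)O)cc2)cc1` differs from compound 2 by dimethylamino in place of methylsulfanyl on an aromatic carbon. Going by the values given here, no measured step shares this change; the one step in hand concerns the carboxy group and not the methylsulfanyl. With compound 2 already at the limit, the expected step to compound 3 is a step that the limit leaves unreadable from compound 2 to compound 3, most likely leaving compound 3 again beyond the top of the assay. Compound 3 is therefore estimated at 150000 nM, with a range from 50000 nM to 500000 nM.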

Compound 3, concentration for 50% growth inhibition: 1000 nM
Compound 3: middle estimate off by 150-fold (2.18 log units), on the high side; the whole stated range lies above it.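

In this assay, dimethylamino in place of methylsulfanyl gives an at least 100-fold lower number from compound 2 to compound 3 (2.00 log units; beyond the scatter). The earlier pair showed only a change at the carboxy-bearing end of the molecule; this step shows that the group on the other aromatic ring, para to a large group, can by itself bring a carboxy compound from the limit to a measured value. The size of the step is only a lower bound, since compound 2 has no number of its own: the limit of > 100000 nM in this assay, at which 1 of the 3 values shown sits.

The compounds shown leave open whether dimethylamino brings a comparable change in the chloro compound 1, and whether another amine at this position, such as pyrrolidine or a primary amine, would do the same. They also leave open how a methyl ester or an amide in place of the carboxylic acid would read alongside dimethylamino.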